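From Cyclopentyl to Cyclohexyl on an Aromatic Oxygen

This account rests on a few compounds, and the source may have more. Where it says the series, first, only, none or still open, it means among the compounds named here.

In a functional assay on HT-29 cells (Homo sapiens) for inhibition, read by sulforhodamine B assay, with a stated time of 48 h (on this read-out lower numbers stand for stronger inhibition of growth and higher numbers for weaker inhibition of growth), compound 1 `c1ccc2cc(NC3=NCCO3)ccc2c1` gives 2000 nM and compound 2 `c1cc(NC2=NCCO2)cc(OC2CCCC2)c1` gives 52200 nM as the higher of the two numbers. That places compound 2 as the weaker inhibitor of growth, by a gap beyond the usual scatter. Compound 3 `c1cc(NC2=NCCO2)cc(OC2CCCCC2)c1` has not yet been measured. It has cyclohexyl in place of cyclopentyl on an oxygen on an aromatic ring, and the counted difference is cyclohexyl in place of cyclopentyl on an oxygen on an aromatic ring for this swap. Among the measured compounds shown here, no measured pair shows the effect of a change at this place alone, so the expectation rests on the change itself. Both groups are non-aromatic rings of carbon only. The expected step of a 1.3-fold lower number from compound 2 to compound 3 (0.12 log units; within the scatter) is therefore a small one toward a lower number and stays within the scatter. In this assay compound 3 is estimated at 40000 nM with a range from 15000 nM to 100000 nM for repeat measurements.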

Compound 3, concentration for 50% growth inhibition: 4400 nM
Compound 3: the middle estimate sits 9.1-fold (0.96 log units) above what was measured, and the stated range ends above it.
By their numbers in this assay, from the lowest: compound 1; then compound 3; then compound 2.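

On an oxygen on an aromatic ring, the exact carbon ring matters: cyclohexyl in place of cyclopentyl gives a 12-fold lower number from compound 2 to compound 3 (1.07 log units; beyond the scatter) in this assay even though both groups are non-aromatic rings of carbon only. Among the compounds shown here, this is the first measured pair that differs in one place, so it is the first direct sign that the number in this assay responds to a change at this position. The data offer no measurement that explains why the six-membered ring gives the lower number.

On these data alone, with a single pair, it remains open whether a larger ring such as cycloheptyl would move the number further in the same direction. It is also unclear how an open chain such as hexyl, or an amine on the cyclohexyl ring, would behave on the same oxygen.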